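The source may hold more compounds than are shown below. What is called first, only, known or untested is meant among the compounds shown, and "the series" means these compounds.

Measured compounds:
compound 1 `COc1ccc(-c2cc(-c3ccc(S(C)(=O)=O)cc3)cnc2N)cn1` — 6.2 mL.min-1.g-1
compound 2 `CS(=O)(=O)c1ccc(-c2cnc(N)c(-c3ccc(C(F)(F)F)cc3)n2)cc1` — 11 mL.min-1.g-1
compound 3 `COc1ccc(-c2nc(-c3ccc(S(C)(=O)=O)cc3)cnc2N)cn1` — 11 mL.min-1.g-1

Of the compounds shown here, three have been measured in an ADME assay (liver) for metabolic stability, with Liver microsome (Homo sapiens) as the target, read by LC-MS, using microsomes; on this read-out lower numbers stand for slow clearance and higher numbers for fast clearance. Compound 1 gives 6.2 mL.min-1.g-1, the lowest of the three numbers, but its neighbours sit close: compound 2 gives 11 mL.min-1.g-1 and compound 3 gives 11 mL.min-1.g-1, and both of these gaps lie within the scatter of repeated measurements. On these numbers compound 1 cannot be set apart from compounds 2 and 3; the three read as a single cluster of similar clearance.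

The unmeasured compound 4 `CCOc1ncc(-c2ccc(S(C)(=O)=O)cc2)cc1-c1ccc(OC)nc1` derives from compound 1 by one change: ethoxy in place of amino on an aromatic carbon. The amino group leaves and an ethoxy group enters, on an aromatic carbon of the six-membered aromatic ring next to the ring nitrogen, ortho to the 6-methoxypyridin-3-yl group and para to a large group.

Going by the values given here, no step of this kind has been measured among the three compounds, so the account has no direct precedent to lean on. Drawing only on compound 1 and its value 6.2 mL.min-1.g-1, the step of a 1.9-fold higher number from compound 1 to compound 4 (0.29 log units; within the scatter) is expected to be modest and upward, with the uncertainty wide enough that no change beyond the scatter would also be unsurprising. Compound 4 is therefore estimated at 12 mL.min-1.g-1, within a range from 5 mL.min-1.g-1 to 30 mL.min-1.g-1.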

Compound 4, intrinsic clearance in microsomes: 14.2 mL.min-1.g-1
Compound 4: middle estimate off by 1.2-fold (0.07 log units), on the low side, and the stated range covers the measured number.
By their numbers in this assay, from the lowest: compounds 1, 2, 3 and 4 (each within the scatter of the next, the first and the last beyond it).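

In this assay, going by these compounds alone, the change of amino to ethoxy on an aromatic carbon next to the ring nitrogen gives a 2.3-fold higher number from compound 1 to compound 4 (0.36 log units; beyond the scatter) as the first step in one place, which the earlier compounds could not provide. It shows that this position is not silent on this read-out: the replacement of amino, which carries a hydrogen-bond donor, by ethoxy, which carries none, goes with a modest rise that lies beyond the scatter. Within the data shown here, the single step changes the donor and the size of the group together, and no measurement at hand bears on why the number rises.

The compounds shown leave open whether the rise goes with the loss of the amino hydrogens or with the ethoxy chain itself, and a methoxy or a methylamino group on the same carbon would tell these two apart. Also open, on these data alone, is whether the same change would read alike on the core of compound 3, which carries the same amino group.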